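A few compounds are considered here, and "the series" means these few. Any claim that something is new, unique, unknown or untested is made for them only; others in the source may bear on it.

Measured compounds:
- compound 1 `COc1ccccc1-c1ccc(Nc2nc(N[C@H]3CC[C@H](N)CC3)nc3c2ncn3C2CCCC2)cc1`: 2320 nM
- compound 2 `N[C@H]1CC[C@H](Nc2nc(Nc3ccc(-c4ccccc4O)cc3)c3ncn(C4CCCC4)c3n2)CC1`: 2080 nM
- compound 3 `COc1ccccc1-c1ccc(Nc2nc(N[C@H]3CC[C@H](N)CC3)nc3c2ncn3C2CCCC2)cn1`: 553 nM

These three numbers come from a functional assay on K562 cells (Homo sapiens) for inhibition, read by fluorescence and resazurin assay, with a stated time of 72 h; on this read-out lower numbers stand for stronger inhibition of growth and higher numbers for weaker inhibition of growth. Compound 2 differs from compound 1 by hydrogen in place of methyl on an oxygen on an aromatic ring. That change gave a 1.1-fold lower number from compound 1 to compound 2 (0.05 log units; within the scatter), so the two compounds cannot be told apart on this read-out. Compound 3 stands apart: its number is the lowest of the three, and its distance to compound 2 and to compound 1 lies beyond the scatter in each case. How the core of compound 3 differs from the core of compound 1 is not broken down here.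

Compound 4 `N[C@H]1CC[C@H](Nc2nc(Nc3ccc(-c4ccccc4O)nc3)c3ncn(C4CCCC4)c3n2)CC1` has not yet been measured in this assay. For the measured compounds named here, it differs from compound 3 by hydrogen in place of methyl on an oxygen on an aromatic ring, which is the same change, at the same place, as the one from compound 1 to compound 2. Because a 1.1-fold lower number from compound 1 to compound 2 (0.05 log units; within the scatter) stayed within the scatter, a similarly small step is expected here, estimated as a 1.1-fold lower number from compound 3 to compound 4 (0.04 log units; within the scatter). Compound 4 is therefore expected to give about 500 nM, most likely between 250 nM and 1100 nM.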

Compound 4, concentration for 50% growth inhibition: 500 nM
Compound 4: the middle estimate sits on the measured number at the digits printed; measured number inside the range.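

In this assay, replacing 2-methoxyphenyl with 2-hydroxyphenyl gives a 1.1-fold lower number from compound 3 to compound 4 (0.04 log units; within the scatter) and so makes no difference that this read-out can detect on the core of compound 3. The same change did just as little on the core of compound 1, so on these two cores it carries over as a change that leaves growth inhibition where it was: the same change on two cores in this assay, a 1.1-fold lower number (0.05 log units; within the scatter) from compound 1 to compound 2 and a 1.1-fold lower number (0.04 log units; within the scatter) from compound 3 to compound 4, 1.0-fold (0.00 log units) apart, within the scatter of two such steps
For the compounds shown here, this rests on only two pairs of compounds, and it shows neither why the change is so small nor that it would stay small on any further core.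

The compounds shown carry only methoxy or hydroxy at this place, so they leave open what an amine, a carboxylic acid or a longer chain such as ethoxy would do there. They also leave open whether the methoxy-to-hydroxy change would stay this small if other parts of the shared core were altered.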